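Lactam in Place of Benzamide on a Fused Core

The compounds below may be only part of what the source reports. "The series", "measured", "known", "first", "only" and "open" are said of these compounds alone.

Measured so far:
compound 1, `O=C(Nc1cnc(NCc2c(F)ccc3c2CCO3)n2cnnc12)c1ccccc1`: 2000 nM
compound 2, `Cc1ncccc1-c1cnc(NCc2c(F)ccc3c2CCO3)c2nn(CC#N)c(=O)n12`: 4000 nM

In a physicochemical assay for solubility, read by LC-MS, in phosphate buffer, with a stated time of 24 h, at pH 7.4 (a higher number here means a more soluble compound, a lower number a less soluble compound), compound 1 gives 2000 nM, the lowest of the two numbers recorded so far. Compound 2 gives 4000 nM in this assay, and the two values lie within the scatter of each other, so neither can be called the more soluble of the pair.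

Compound 3, `C[C@@H]1CC(=O)N(c2cnc(NCc3c(F)ccc4c3CCO4)n3cnnc23)C1`, has not yet been measured. It is compound 1 with one change: 4-methyl-2-oxopyrrolidin-1-yl in place of benzamido on an aromatic carbon. Going by the values given here, no pair of measured compounds differs in a single place, so no measured step guides the expectation; it rests on compound 1 and its value of 2000 nM in this assay.

The step of a 4.0-fold higher number from compound 1 to compound 3 (0.60 log units; beyond the scatter) is expected to be upward and somewhat beyond the scatter, but not large. Compound 3 is expected to give 8000 nM in this assay, with a range from 2500 nM to 25000 nM covering most repeat measurements.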

Compound 3, solubility: 130000 nM
Compound 3: middle estimate off by 16-fold (1.21 log units), on the low side; the whole stated range lies below it.
By their numbers in this assay, from the lowest: compounds 1 and 2 (each within the scatter of the next); then compound 3.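

This position, on an aromatic carbon of a six-membered aromatic ring with 2 nitrogen, now has a measured step: in this assay, 4-methyl-2-oxopyrrolidin-1-yl in place of benzamido gives a 65-fold higher number from compound 1 to compound 3 (1.81 log units; beyond the scatter), a large change well beyond the scatter. Compound 1 and compound 2 differ in more than one place, so they could not show how much a single exchange at this position can move the number. The exchange alters several things at once: the six-membered aromatic ring of carbon only and the hydrogen-bond donor leave, while a five-membered non-aromatic ring and a defined stereocentre enter, and this one step cannot separate them.

No measurement available here bears on why the number moves so far. From the compounds shown here alone, it remains open whether N-methylbenzamido, which keeps the aromatic ring without the amide hydrogen, would stand nearer to compound 1 or to compound 3, and whether 2-oxopyrrolidin-1-yl without the methyl, the opposite enantiomer of the methyl lactam, or 2-oxopiperidin-1-yl would give a similar number in this assay.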